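This account rests on a few compounds, and the source may have more. Where it says the series, first, only, none or still open, it means among the compounds named here.

Working notes on the series. Compound 3 `COc1ccc(S(=O)(=O)c2nc3ccccc3nc2Nc2cc(OC)cc(OC)c2)cc1` is one of three analogues sharing a core built around an aryl sulfone and an aryl amine on the same aromatic ring. In a functional assay on PC-3 cells (Homo sapiens) for cytotoxicity, read by MTT assay, with a stated time of 72 h (a lower number here means a stronger inhibitor, a higher number a weaker inhibitor), compound 3 gives 6220 nM, the second highest of the three numbers; its nearest neighbour is compound 1 `Cc1ccc(S(=O)(=O)c2nc3ccccc3nc2Nc2ccc(N)cc2)cc1`, which gives 5000 nM, and its furthest is compound 2 `COc1ccc(Nc2nc3ccccc3nc2S(=O)(=O)c2ccc(OC)cc2)cc1`, which gives 8710 nM, both gaps lying within the scatter. Within the data shown here, the step of a 1.4-fold lower number from compound 2 to compound 3 (0.15 log units; within the scatter) is the only measured change at the aryl amine, and it stays within the scatter.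

Compound 4 `COc1ccc(S(=O)(=O)c2nc3ccccc3nc2Nc2ccc(N)cc2)cc1` is not yet measured. It differs from compound 3 by 4-aminophenyl in place of 3,5-dimethoxyphenyl on a nitrogen on an aromatic ring. Among the measured compounds shown here, no measured step covers this exact exchange; compound 1 already carries the 4-aminophenyl group, though with a different aryl on the sulfone, so its value only shows where that group has landed before. For the measured compounds named here, with the one measured step at this place being within the scatter, no shift beyond the scatter is expected here, and the step of a 1.1-fold lower number from compound 3 to compound 4 (0.05 log units; within the scatter) is the estimated outcome. Compound 4 is therefore expected to give 5500 nM in this assay, with a range of 2500 nM to 12000 nM.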

Compound 4, half-maximal inhibitory concentration: 9640 nM
Beside the measured number, compound 4's estimate is 1.8-fold (0.24 log units) below it; the measured number falls inside the stated range.
By their numbers in this assay, from the lowest: compounds 1, 3, 2 and 4 (each within the scatter of the next).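

In this assay, the aryl amine now has a second and a third measured exchange: 4-aminophenyl in place of 3,5-dimethoxyphenyl on a nitrogen on an aromatic ring gives a 1.5-fold higher number from compound 3 to compound 4 (0.19 log units; within the scatter), and amino in place of methoxy on an aromatic carbon gives a 1.1-fold higher number from compound 2 to compound 4 (0.04 log units; within the scatter), so three different aryl groups at this place remain within the scatter of each other. The first measured change away from the aryl amine, methoxy in place of methyl on an aromatic carbon, gives a 1.9-fold higher number from compound 1 to compound 4 (0.29 log units; within the scatter), which also stays within the scatter. Nothing available bears on the reason for these numbers.

The compounds shown leave open whether any exchange at either place moves the number beyond the scatter. As far as these compounds go, how a carboxylic acid or a chlorine in place of the amino group would read also remains open.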